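Cyano in Place of Hydrogen on the Core of Compound 3

A few compounds are considered here, and "the series" means these few. Any claim that something is new, unique, unknown or untested is made for them only; others in the source may bear on it.

The study follows a small set of sulfonamide-linked compounds sharing one core. Compound 1 `CN(C)CC[C@H](CSc1ccccc1)Nc1ccc(S(=O)(=O)NC(=O)c2ccc(N3CCN(Cc4ccccc4-c4ccc(Cl)cc4)CC3)cc2)cc1C(F)(F)F` was examined in an ADME assay on the whole organism (plasma, strain Sprague-Dawley) for pharmacokinetics, with Rattus norvegicus as the target, at a dose of 5 mg/kg by the oral route (a higher number here means more compound in the circulation at the dose given, a lower number less compound in the circulation), and gives 3690 ng.h/mL. Compound 2 `Cc1cc(S(=O)(=O)NC(=O)c2ccc(N3CCN(Cc4ccccc4-c4ccc(Cl)cc4)CC3)cc2)ccc1N[C@H](CCN(C)C)CSc1ccccc1` was entered in this assay but for compound 2 the outcome is recorded as "not determined" (no result reported). Compound 3 `CN(C)CC[C@H](CSc1ccccc1)Nc1ccc(S(=O)(=O)NC(=O)c2ccc(N3CCN(Cc4ccccc4-c4ccc(Cl)cc4)CC3)cc2)cc1` is in the same position: in this assay compound 3 stands at "not determined" (no result reported), so no single number fixes where it lies, and the only real anchor in the set is compound 1.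

Compound 4 `CN(C)CC[C@H](CSc1ccccc1)Nc1ccc(S(=O)(=O)NC(=O)c2ccc(N3CCN(Cc4ccccc4-c4ccc(Cl)cc4)CC3)cc2)cc1C#N` is the untested member. It differs from compound 3 by cyano in place of hydrogen on an aromatic carbon. Among the measured compounds shown here, no measured pair in the set shows what this kind of change does in this assay, and compound 3 itself carries no number, so the direction and size of the step are unknown; a shift within the usual scatter, or somewhat beyond it in either direction, is equally defensible. Taking compound 1 as the only measured reference in this assay, compound 4 is expected to give about 2500 ng.h/mL, with a plausible range from 600 ng.h/mL to 8000 ng.h/mL.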

Compound 4, area under the concentration-time curve: 1740 ng.h/mL
Compound 4: middle estimate off by 1.4-fold (0.16 log units), on the high side; the range from low to high includes it.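

Compound 4 gives the set its first readable step at this place on the shared core, the aromatic carbon ortho to a large group and meta to a large group. In this assay, cyano in place of trifluoromethyl gives a 2.1-fold lower number from compound 1 to compound 4 (0.33 log units; beyond the scatter), a modest change but one beyond the scatter, so with the rest of the structure held constant, the choice between these two groups registers in the read-out, with the higher number belonging to the trifluoromethyl compound. Every step involving compound 2 or compound 3 cannot be read, since neither has a number, and so the effect of cyano in place of hydrogen stays unknown; nothing available bears on why the number differs between compound 1 and compound 4.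

The compounds shown thus leave open whether trifluoromethyl and cyano both lie above or below the unsubstituted compound 3, or on opposite sides of it. They also do not show how other groups at this place, such as a chlorine atom, a methoxy group or a carboxylic acid, would stand against these two in this assay.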